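Removing a Ring Methyl from the Aryl Ether of Compound 1

The compounds below may be only part of what the source reports. "The series", "measured", "known", "first", "only" and "open" are said of these compounds alone.

Compound 1 `Cc1cccc(N(C)C(=O)c2ccc(Oc3ccccc3C)cc2)c1` has the highest number of the three measured compounds in an assay on microsomes from placenta for inhibition of 17-beta-hydroxysteroid dehydrogenase type 2 (Homo sapiens), read by HPLC, with a stated time of 20 min, tested at 1 uM (on this read-out higher numbers stand for more inhibition at the one concentration tested (going by the name of the read-out) and lower numbers for less inhibition), where compound 1 gives 55%. The two piperazine sulfonamides sit lower: compound 2 `O=S(=O)(c1cccc(O)c1)N1CCN(c2cccc(O)c2)CC1` gives 25% in this assay, and compound 3 `COc1cccc(S(=O)(=O)N2CCN(c3ccc(F)c(OC)c3)CC2)c1` gives 15%. Both gaps from compound 1 lie beyond the usual scatter, so compound 1 stands clearly on top of the numbers seen so far.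

Compound 4 `Cc1cccc(N(C)C(=O)c2ccc(Oc3ccccc3)cc2)c1` keeps the core of compound 1 and changes only the aryl ether: hydrogen in place of methyl on an aromatic carbon, on the aromatic carbon ortho to a large group. Among the measured compounds shown here, no measured pair here isolates this change, so its size is not known from the data. The step from compound 1 to compound 4 is expected to be small, a number 10 percentage points lower from compound 1 to compound 4 (within the scatter), leaning downward but possibly within the scatter. Compound 4 is therefore estimated to give 45% in this assay, expected to fall between 20% and 68%.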

Compound 4, a percentage reported as inhibition, at one concentration (the size of the read-out at that concentration, not a potency): 59%
The estimate for compound 4 lay 14 percentage points below the measured number; low and high end bracket the measured number.
By their numbers in this assay, from the lowest: compounds 3 and 2 (each within the scatter of the next); then compounds 1 and 4 (each within the scatter of the next).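

In this assay, among the compounds shown here, hydrogen in place of methyl on an aromatic carbon, ortho to a large group, gives a number 4 percentage points higher from compound 1 to compound 4 (within the scatter), the only step here between compounds that differ in one place. The change from 2-methylphenyl to phenyl thus leaves the read-out unresolved at the one concentration tested, and the phenoxy compound cannot be ranked against the 2-methylphenoxy compound. Nothing at hand explains this result.

The compounds shown leave open whether a longer chain such as ethyl, a methoxy group, an amine or a carboxylic acid on this aromatic carbon would give a read-out like those of compound 1 and compound 4. They also leave open whether compound 1 and compound 4 would still read alike at other concentrations.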